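The source may hold more compounds than are shown below. What is called first, only, known or untested is meant among the compounds shown, and "the series" means these compounds.

Measured so far in an assay on isolated protein for inhibition of RAC-alpha serine/threonine-protein kinase (Homo sapiens), tested at 30 uM; on this read-out lower numbers stand for less inhibition and higher numbers for more inhibition at the one concentration tested (going by the name of the read-out):

- compound 1 `Clc1ncnc2ncn(Cc3ccccc3)c12` gives 0%
- compound 2 `Fc1ccc(Cn2cnc3ncnc(Cl)c32)cc1` gives 0%
- compound 3 `CSc1ccc(-c2nc3c(Sc4ccccc4)ncnc3n2C)cc1` gives 5%

Compound 2 differs from compound 1 by fluoro in place of hydrogen on an aromatic carbon, and the step of no change at the digits printed from compound 1 to compound 2 (within the scatter). Compound 3 is built on a different core; the difference between the cores of compound 1 and compound 3 is not broken down here. In this assay compound 3 and compound 1 sit within the scatter of each other, as do compound 3 and compound 2.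

Compound 4 `CSc1ccc(-c2nc3c(Sc4ccc(F)cc4)ncnc3n2C)cc1` has not yet been measured. It differs from compound 3 by fluoro in place of hydrogen on an aromatic carbon, the same change as that from compound 1 to compound 2, with the place described in the same words. The step of no change at the digits printed from compound 3 to compound 4 (within the scatter) is expected because no change at the digits printed from compound 1 to compound 2 (within the scatter) on the core of compound 1. For compound 4 in this assay the expected value is 5%, with a range estimated from 0% to 15%.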

Compound 4, a percentage reported as inhibition, at one concentration (the size of the read-out at that concentration, not a potency): 0%
Compound 4: the middle estimate sits 5 percentage points above what was measured; low and high end bracket the measured number.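

In this assay, fluoro in place of hydrogen on an aromatic carbon gives a number 5 percentage points lower from compound 3 to compound 4 (within the scatter). Set beside the earlier step, the change reads the same on both cores: the same change on two cores in this assay, no change at the digits printed (within the scatter) from compound 1 to compound 2 and a number 5 percentage points lower (within the scatter) from compound 3 to compound 4, 5 percentage points apart, within the scatter of two such steps This shows that the change carries from one core to the other without a step beyond the scatter, but with so little inhibition on either core, it does not show how the change would carry over in a compound with clear inhibition.

As far as these compounds go, whether an amine or a carboxylic acid at the same place on the ring would move the number in this assay stays open. So does whether any group on these cores gives clear inhibition.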